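The source may hold more compounds than are shown below. What is called first, only, known or untested is meant among the compounds shown, and "the series" means these compounds.

Three compounds share a core of two fused rings that carries a benzyl group bearing a chloromethyl arm. Compound 1 `ClCc1cccc(Cn2cnc3c(Cl)nc(Cl)nc32)c1` has two chloro groups on its core and compound 3 `ClCc1ccccc1Cn1cnc2ncnc(Cl)c21` has one. Compound 2 `Nc1nc(Cl)c2ncn(Cc3ccccc3CCl)c2n1` has one chloro group and one amino group. In a functional assay on M14 cells (Homo sapiens) for cytotoxicity, read by sulforhodamine B assay, with a stated time of 48 h (on this read-out higher numbers stand for weaker inhibition of growth and lower numbers for stronger inhibition of growth), compound 1 gives 1770 nM, compound 3 gives 1900 nM and compound 2 gives 5750 nM. Compound 2 thus stands highest of the three numbers, meaning it holds back growth least; both other compounds lie beyond the scatter below it, compound 3 nearest and compound 1 furthest.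

Compound 4 `ClCc1ccccc1Cn1cnc2c(Cl)ncnc21` is not yet measured. It differs from compound 2 in one place: hydrogen in place of amino on an aromatic carbon. Going by the values given here, no measured pair isolates exactly this change. The step of a 2.9-fold lower number from compound 2 to compound 4 (0.46 log units; beyond the scatter) is nevertheless expected to run toward stronger growth inhibition, because compound 1 gives 1770 nM and compound 3 gives 1900 nM while both lack an amino group and both sit beyond the scatter below compound 2. Compound 4 is therefore estimated at 2000 nM, within a range from 800 nM to 6000 nM.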

Compound 4, concentration for 50% growth inhibition: 1950 nM
Beside the measured number, compound 4's estimate is 1.0-fold (0.01 log units) above it, and the stated range covers the measured number.
By their numbers in this assay, from the lowest: compounds 1, 3 and 4 (each within the scatter of the next); then compound 2.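

In this assay replacing amino with hydrogen on this aromatic carbon, between two ring nitrogen atoms, gives a 2.9-fold lower number from compound 2 to compound 4 (0.47 log units; beyond the scatter) and so a modest move toward stronger growth inhibition. Going by these compounds alone, this pair gives the first direct reading of the change, since the two structures differ in this one place alone, and it shows that the amino group at this position goes with weaker growth inhibition in this pair. No measurement shown explains why the number moves with this change.

On these data alone, whether a methyl group, a hydroxyl group or a dimethylamino group on this same carbon would give a number nearer compound 2 or compound 4 remains open. Also open, as far as these compounds go, is whether the step would hold with the chloromethyl arm elsewhere on the benzyl group.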